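The source may report more compounds than this note shows. Statements on the series, on what has been measured and on what is new or still open speak of the compounds shown alone.

The measured compounds:

Compound 1, `O=C(Nc1ccccc1)Nc1nc2ccc(F)cc2s1`. In a functional assay on SK-HEP1 cells (Homo sapiens) for antiproliferative activity, read by sulforhodamine B assay (a lower number here means a stronger inhibitor of growth, a higher number a weaker inhibitor of growth), compound 1 gives only a limit, > 10 ug/mL.
Compound 2, `O=C(Nc1cccc([N+](=O)[O-])c1)Nc1nc2ccc(F)cc2s1`. In this assay compound 2 gives 1.96 ug/mL.

Within the data shown here, compound 2 is thus the only compound with a true number in this assay; the other value is a limit (the limit of > 10 ug/mL in this assay, at which 1 of the 2 values shown sits). Among the measured compounds shown here, the one measured step, an at least 5.1-fold lower number from compound 1 to compound 2 (0.70 log units; beyond the scatter), concerns the nitro on the phenyl ring, not the fused core.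

Compound 3, `Cc1ccc2nc(NC(=O)Nc3cccc([N+](=O)[O-])c3)sc2c1`, differs from compound 2 in methyl in place of fluoro on an aromatic carbon. No measured step touches this position, so nothing shown speaks directly for or against the exchange, and compound 3 is expected to stay close to compound 2, with a step of a 1.1-fold higher number from compound 2 to compound 3 (0.05 log units; within the scatter) that lies within the scatter. Compound 3 is therefore estimated at 2.2 ug/mL in this assay, in a range of 0.7 ug/mL to 7 ug/mL.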

Compound 3, concentration for 50% growth inhibition: > 10 ug/mL
Compound 3 ended at the assay's limit (the forecaster's own chance of this, stated with the estimate: 20%); at least 4.5-fold (0.65 log units) between middle value and limit.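

Among these compounds, this position on the six-membered aromatic ring of the shared core is not a neutral spot, as it had seemed while no measured step touched it: methyl in place of fluoro gives an at least 5.1-fold higher number from compound 2 to compound 3 (0.70 log units; beyond the scatter) in this assay. Compound 3 keeps the nitro on the phenyl ring, so that nitro does not secure a measurable growth inhibition without the fluoro. Compound 3 gives only a limit, so the step marks a smallest size and its full size stays unknown, and the true number is shown for only one compound: the limit of > 10 ug/mL in this assay, at which 2 of the 3 values shown sit.

As far as these compounds go, whether hydrogen, chloro, methoxy or an amine at this position would behave like fluoro or like methyl remains open. So does whether a carboxylic acid or a longer chain would be tolerated here.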